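Lengthening the Saturated Chain of Compound 2

The source may report more compounds than this note shows. Statements on the series, on what has been measured and on what is new or still open speak of the compounds shown alone.

Values measured in a functional assay on HCT-116 cells (Homo sapiens) for antiproliferative activity, read by MTT assay, with a stated time of 48 h (on this read-out higher numbers stand for weaker inhibition and lower numbers for stronger inhibition), for two compounds:
- Compound 1 `CCCCCCCCCC(CCO)n1cnc2c(OC)ncnc21` gives 2530 nM
- Compound 2 `CCCCCCCCCC(CCO)n1cnc2c(N(C)C)ncnc21` gives 9810 nM

Compound 2 holds the higher of the two numbers, so it is the weaker inhibitor of the pair. Compound 3 `CCCCCCCCCCCC(CCO)n1cnc2c(N(C)C)ncnc21` keeps its dimethylamino group and changes only the saturated chain, and ethyl in place of hydrogen on a saturated chain carbon, ten or more bonds along the chain from an aromatic nitrogen is the whole difference. Within the data shown here, the one measured step, a 3.9-fold higher number from compound 1 to compound 2 (0.59 log units; beyond the scatter), is modest and puts dimethylamino in place of methoxy on an aromatic carbon, which is a different place. Among the measured compounds shown here, no measured pair shows what a chain change does, so this step offers only a rough sense of size and no direction. A step of similar or smaller size, in either direction, is therefore expected in this assay for this change. The expected step is a 1.2-fold lower number from compound 2 to compound 3 (0.09 log units; within the scatter) as a best guess. Compound 3 is expected at 8000 nM, with an estimated range from 3000 nM to 22000 nM around it.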

Compound 3, half-maximal inhibitory concentration: 12000 nM
Compound 3: the middle estimate sits 1.5-fold (0.18 log units) below what was measured; measured number inside the range.
By their numbers in this assay, from the lowest: compound 1; then compounds 2 and 3 (each within the scatter of the next).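

In this assay, ethyl in place of hydrogen on a saturated chain carbon, ten or more bonds along the chain from an aromatic nitrogen, gives a 1.2-fold higher number from compound 2 to compound 3 (0.09 log units; within the scatter). Among these compounds, this is the first measured change to the chain, and the numbers of the two compounds cannot be told apart, whereas the swap of methoxy for dimethylamino, a 3.9-fold higher number from compound 1 to compound 2 (0.59 log units; beyond the scatter), remains the only step here beyond the scatter. No measurement offered here accounts for this result.

On these data alone, it remains open whether a much longer chain, or a carboxylic acid or an amine in the same place, would also stay within the scatter of compound 2. As far as these compounds go, it is also open whether the same ethyl change would read alike on compound 1, which carries methoxy rather than dimethylamino.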